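The source may report more compounds than this note shows. Statements on the series, on what has been measured and on what is new or still open speak of the compounds shown alone.

Compound 1 `COc1ccc(/C=C/C2CC=CC(=O)N2)cc1` gives 842 uM in a functional assay on NCI/ADR cells (Homo sapiens) for inhibition, read by sulforhodamine B assay, with a stated time of 48 h; a higher number here means a weaker inhibitor of growth, a lower number a stronger inhibitor of growth. Compound 2 `COc1ccc(/C=C/C2CC=CC(=O)N2)c(OC)c1` sits at the limit of > 964 uM in this assay, at which 1 of the 3 values shown sits, and so gives > 964 uM only as a limit, not a number. Compound 3 `COc1cc(/C=C/C2CC=CC(=O)N2)cc(OC)c1` gives 203 uM.

Compound 1 and compound 2 differ by methoxy in place of hydrogen on an aromatic carbon, and that change gave an at least 1.1-fold higher number from compound 1 to compound 2 (0.05 log units; that floor lies within the scatter). The difference between the core of compound 1 and the core of compound 3 is not broken down here.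

Compound 4 `COc1cc(/C=C/C2CC=CC(=O)N2)cc(OC)c1OC` is not yet measured. It differs from compound 3 by methoxy in place of hydrogen on an aromatic carbon. This is the same kind of change as from compound 1 to compound 2, but the surroundings differ: there the methoxy entered ortho to a group of 9 heavy atoms and meta to a methoxy group, here it enters ortho to two methoxy groups and para to a group of 9 heavy atoms. Going by the values given here, the one measured step gives little to go on, so compound 4 is expected to stay close to compound 3, with a 1.4-fold lower number from compound 3 to compound 4 (0.13 log units; within the scatter). Compound 4 is therefore estimated at 150 uM, between 40 uM and 600 uM.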

Compound 4, concentration for growth inhibition (reported as GI): > 864 uM
Compound 4: a limit, no number; the forecaster's own chance of this, stated with the estimate: 15%; at least 5.7-fold (0.76 log units) between middle value and limit.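

On the core of compound 3, methoxy in place of hydrogen on an aromatic carbon gave an at least 4.2-fold higher number from compound 3 to compound 4 (0.62 log units; beyond the scatter) in this assay, a clear loss of growth inhibition. Going by these compounds, compound 4 gives > 864 uM as a limit, not a number, so the full size of this step stays unknown. The change therefore did not leave activity intact on this core, but the data do not show whether it acts to the same extent on both cores: the same change on two cores in this assay, an at least 1.1-fold higher number (0.05 log units; that floor lies within the scatter) from compound 1 to compound 2 and an at least 4.2-fold higher number (0.62 log units; beyond the scatter) from compound 3 to compound 4; the limit leaves it open whether they differ.

The compounds shown leave open how other groups at this place on the aromatic ring would behave, such as a hydroxy group, an amine or a carboxylic acid. They also leave open whether a longer chain in place of methoxy would be tolerated.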